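From 3-methoxyphenyl to 4-nitrophenyl in a small series

A few compounds are considered here, and "the series" means these few. Any claim that something is new, unique, unknown or untested is made for them only; others in the source may bear on it.

In a functional assay on A549 cells (Homo sapiens) for antiproliferative activity, read by MTT assay, with a stated time of 48 h (on this read-out lower numbers stand for stronger inhibition and higher numbers for weaker inhibition), compound 3 `COc1cccc(-c2nn(-c3ccccc3)cc2C(Nc2nc3ccccc3s2)c2c(O)ccc3ccccc23)c1` gives 24800 nM, which lies within the scatter of compound 2 `Oc1ccc2ccccc2c1C(Nc1nc2ccccc2s1)c1cn(-c2ccccc2)nc1-c1ccccc1` at 36200 nM. Compound 1 `Cc1ccc2nc(NC(c3cn(-c4ccccc4)nc3-c3cccc([N+](=O)[O-])c3)c3c(O)ccc4ccccc34)sc2c1`, at 57400 nM, stands beyond the scatter of compound 3, with a higher number.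

Compound 4 `O=[N+]([O-])c1ccc(-c2nn(-c3ccccc3)cc2C(Nc2nc3ccccc3s2)c2c(O)ccc3ccccc23)cc1` carries 4-nitrophenyl in place of the 3-methoxyphenyl of compound 3, on an aromatic carbon of a five-membered aromatic ring with 2 nitrogen (4-nitrophenyl in place of 3-methoxyphenyl on an aromatic carbon).

Going by the values given here, the only measured step at this group, a 1.5-fold lower number from compound 2 to compound 3 (0.16 log units; within the scatter), is methoxy in place of hydrogen and stays within the scatter. Among the compounds with values here, compound 1, the only measured compound with a nitrophenyl group, gives 57400 nM, but it differs from compound 4 in more than one place and so offers only a loose guide. In this assay, a small move towards a higher number is therefore expected, with no clear step beyond the scatter. The expected change is a 1.4-fold higher number from compound 3 to compound 4 (0.15 log units; within the scatter). For compound 4 the estimated value is 35000 nM, with an expected range from 15000 nM to 80000 nM.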

Compound 4, half-maximal inhibitory concentration: 41300 nM
Estimate against measurement, compound 4: 1.2-fold (0.07 log units) below; measured number inside the range.
By their numbers in this assay, from the lowest: compounds 3, 2, 4 and 1 (each within the scatter of the next, the first and the last beyond it).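

In this assay, 4-nitrophenyl in place of 3-methoxyphenyl, at the carbon next to the ring nitrogen, gives a 1.7-fold higher number from compound 3 to compound 4 (0.22 log units; within the scatter), and nitro in place of hydrogen on an aromatic carbon gives a 1.1-fold higher number from compound 2 to compound 4 (0.06 log units; within the scatter). With the earlier methoxy step, this places compounds 2, 3 and 4 all within the scatter of one another, so at this position neither the methoxy nor the nitro group separates from the hydrogen of compound 2, and the exchange of one for the other does not separate them either. Nothing available explains why these numbers lie so close together.

From the compounds shown here alone, it remains open whether an amine or a carboxylic acid on this phenyl ring would give a step beyond the scatter. The compounds shown also do not tell whether any group at this position could bring the number well below those seen here.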